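Swapping hydroxycarbamoyl for (2-aminophenyl)carbamoyl on compound 1

The source may hold more compounds than are shown below. What is called first, only, known or untested is meant among the compounds shown, and "the series" means these compounds.

In a functional assay on MCF7 cells (Homo sapiens) for antiproliferative activity, read by CCK-8 assay, with a stated time of 72 h (a higher number here means a weaker inhibitor, a lower number a stronger inhibitor), compound 1 (`CCOc1cc(C(C)(C)C)ccc1C1=NC(c2ccc(Cl)cc2)C(c2ccc(Cl)cc2)N1C(=O)NCCCCCCCC(=O)NO`) gives 7920 nM as its value. Compound 2 (`CCOc1cc(C(C)(C)C)ccc1C1=NC(c2ccc(Cl)cc2)C(c2ccc(Cl)cc2)N1C(=O)N1CCN(CCCCC(=O)NO)CC1`) gives 9800 nM and compound 3 (`CCOc1cc(C(C)(C)C)ccc1C1=NC(c2ccc(Cl)cc2)C(c2ccc(Cl)cc2)N1C(=O)NCc1ccc(C(=O)NO)cc1`) gives 13300 nM on the same read-out, so compound 1 stands within the usual scatter of both. Compound 4 (`CCOc1cc(C(C)(C)C)ccc1C1=NC(c2ccc(Cl)cc2)C(c2ccc(Cl)cc2)N1C(=O)NCCCCCC(=O)Nc1ccccc1N`) keeps the shared core but differs from compound 1 at the end of the chain ((2-aminophenyl)carbamoyl in place of 2-(hydroxycarbamoyl)ethyl on a saturated chain carbon, five bonds along the chain from an amide-type nitrogen). For the measured compounds named here, the one measured step that bears on this is a 1.7-fold higher number from compound 1 to compound 3 (0.23 log units; within the scatter) and it put 4-(hydroxycarbamoyl)phenyl in place of 6-(hydroxycarbamoyl)hexyl. Going by the values given here, that step kept the hydroxycarbamoyl group, and no measured compound lacks it, so the new end group is untested here and the range must stay wide. With the three values this close, the expected change in this assay is a 1.1-fold higher number from compound 1 to compound 4 (0.06 log units; within the scatter) and thus none beyond the scatter. The estimate for compound 4 is 9000 nM (range 3500 nM to 25000 nM).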

Compound 4, half-maximal inhibitory concentration: > 100000 nM
Compound 4 ended at the assay's limit (the forecaster's own chance of this, stated with the estimate: 10%); middle value at least 11-fold (1.04 log units) from the limit.
By their numbers in this assay, from the lowest: compounds 1, 2 and 3 (each within the scatter of the next). At a limit, above all of these: compound 4.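

In this assay compound 4 reads > 100000 nM, which is a limit of the assay and not a number: the limit of > 100000 nM in this assay, at which 1 of the 4 values shown sits.

Even so, the end group makes a large difference, with an at least 12-fold higher number from compound 1 to compound 4 (1.10 log units; beyond the scatter), while the one measured change of linker that keeps hydroxycarbamoyl gives a 1.7-fold higher number from compound 1 to compound 3 (0.23 log units; within the scatter). Among these compounds, then, replacing hydroxycarbamoyl with (2-aminophenyl)carbamoyl at the end of the chain matters far more than that change of linker.

The compounds shown do not separate the removal of hydroxycarbamoyl from the arrival of the aromatic ring and its amine, as compound 4 differs in all of these at once. A carboxylic acid or a phenylcarbamoyl group without the amine at this place would bear directly on that question.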